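Ortho-alkyl anilide sulfonamide ureas: methyl to ethyl step

The source may hold more compounds than are shown below. What is called first, only, known or untested is meant among the compounds shown, and "the series" means these compounds.

Measured compounds in a functional assay on HT-29 cells (Homo sapiens) for cytotoxicity, read by sulforhodamine B assay, with a stated time of 48 h; on this read-out higher numbers stand for weaker inhibition and lower numbers for stronger inhibition:
- compound 1 `Cc1ccccc1NS(=O)(=O)c1ccc(NC(=O)NCCCCl)cc1`: 64000 nM
- compound 2 `CCc1ccccc1NS(=O)(=O)c1ccc(NC(=O)NCCCCl)cc1`: a limit, > 200000 nM
- compound 3 `CCNC(=O)Nc1ccc(S(=O)(=O)Nc2ccccc2C)cc1`: a limit, > 200000 nM

Compound 3 sits at the limit of this assay and carries no number, sharing the limit of > 200000 nM in this assay, at which 2 of the 3 values shown sit, with one other compound. Going by the values given here, compound 1 is the only member of the series with a numerical value.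

Compound 4 `CCNC(=O)Nc1ccc(S(=O)(=O)Nc2ccccc2CC)cc1` is not yet measured. It differs from compound 3 by methyl in place of hydrogen on a saturated chain carbon bound to an aromatic carbon, the same change that separates compound 1 from compound 2. That measured step, an at least 3.1-fold higher number from compound 1 to compound 2 (0.49 log units; beyond the scatter), went to the limit and was therefore at least modest in the direction of weaker inhibition. The other measured step, an at least 3.1-fold higher number from compound 1 to compound 3 (0.49 log units; beyond the scatter), also reached the limit; neither gives a reason, and no evidence on properties of the groups exists.

For compound 4, then, a step that the limit leaves unreadable from compound 3 to compound 4 is expected, starting from a compound already at the limit, so the assay is expected to return only a limit again. The estimate for compound 4 in this assay is 600000 nM, within 200000 nM to 3000000 nM.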

Compound 4, half-maximal inhibitory concentration: 86000 nM
The estimate for compound 4 lay 7.0-fold (0.84 log units) above the measured number; the measured number lies below the stated range.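

Taken without the chloromethyl group, the change from methyl to ethyl gives an at least 2.3-fold lower number from compound 3 to compound 4 (0.36 log units; beyond the scatter) in this assay and so runs opposite to the earlier step on the core bearing chloromethyl. A longer group at this position therefore carries no fixed direction in this series, and its outcome depends on what stands at the other end of the molecule: the same change on two cores in this assay, an at least 3.1-fold higher number (0.49 log units; beyond the scatter) from compound 1 to compound 2 and an at least 2.3-fold lower number (0.36 log units; beyond the scatter) from compound 3 to compound 4, at least 7.2-fold (0.86 log units) apart, beyond the scatter of two such steps

The same reversal appears when the chloromethyl group is replaced by hydrogen with ethyl in place, which gives an at least 2.3-fold lower number from compound 2 to compound 4 (0.36 log units; beyond the scatter) and turns the earlier direction around: the same change on two cores in this assay, an at least 3.1-fold higher number (0.49 log units; beyond the scatter) from compound 1 to compound 3 and an at least 2.3-fold lower number (0.36 log units; beyond the scatter) from compound 2 to compound 4, at least 7.2-fold (0.86 log units) apart, beyond the scatter of two such steps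

The true size of both new steps stays unread, since compound 2 and compound 3 each sit at a limit of the assay and carry no number: the limit of > 200000 nM in this assay, at which 2 of the 4 values shown sit.

Going by these compounds, whether a propyl group or a longer chain at this position keeps the gain seen on the core without chloromethyl remains open, as does the outcome with an amine or a carboxylic acid at the end of the urea chain.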